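Cyano in Place of Methoxy on a Shared Aromatic Core

This account rests on a few compounds, and the source may have more. Where it says the series, first, only, none or still open, it means among the compounds named here.

Of the compounds shown here, two on a shared core have been measured in a physicochemical assay for lipophilicity, at pH 7.4; on this read-out lower numbers stand for lower lipophilicity and higher numbers for higher lipophilicity. Compound 1 `Cc1nn(C)c(C)c1-c1ccc(-c2nnc(N(C)Cc3ccc4nccn4c3)o2)cc1` gives 3.1 in this assay. Compound 2 `COc1cc(-c2c(C)nn(C)c2C)ccc1-c1nnc(N(C)Cc2ccc3nccn3c2)o1` gives 2.9 in this assay and so stands at the lower of the two numbers, with compound 1 the nearest neighbour and within the scatter of it. Among the compounds with values here, the single measured step, a number 0.20 log units lower from compound 1 to compound 2 (within the scatter), came with methoxy in place of hydrogen on an aromatic carbon. Compound 3 `Cc1nn(C)c(C)c1-c1ccc(-c2nnc(N(C)Cc3ccc4nccn4c3)o2)c(C#N)c1` has not yet been measured. It differs from compound 2 in one place: cyano in place of methoxy on an aromatic carbon. Within the data shown here, no measured step involves a cyano group, so the only step that bears on this change is the hydrogen-to-methoxy step, which stayed within the scatter. Compound 3 is nonetheless expected to give a lower number in this assay, by an estimated a number 0.40 log units lower from compound 2 to compound 3 (beyond the scatter). The estimate for compound 3 is 2.5, expected to fall between 2.1 and 2.9.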

Compound 3, distribution coefficient: 2.9
Compound 3: the middle estimate sits 0.40 log units below what was measured; the measured number falls inside the stated range.
By their numbers in this assay, from the lowest: compounds 2, 3 and 1 (each within the scatter of the next).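

In this assay cyano in place of methoxy on this aromatic carbon, ortho to a large group and meta to a 1,3,5-trimethyl-1H-pyrazol-4-yl group, gave no change at the digits printed from compound 2 to compound 3 (within the scatter) and cyano in place of hydrogen at the same carbon gave a number 0.20 log units lower from compound 1 to compound 3 (within the scatter) as its result. Hydrogen, methoxy and cyano at this position are therefore not told apart by this read-out, and the entry of a triple bond outside the aromatic rings left the number within the scatter, as the methoxy step had done. No evidence on hand accounts for this outcome.

On these data alone, whether this position stays as undiscriminating with other groups remains open, since an amine or a carboxylic acid on this carbon could read quite differently. Also open, as far as these compounds go, is whether cyano or methoxy on another carbon of the same aromatic ring would behave as they do here.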